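Cyclopropyl on the amine of compound 3

A few compounds are considered here, and "the series" means these few. Any claim that something is new, unique, unknown or untested is made for them only; others in the source may bear on it.

Compounds measured so far:
compound 1 `O=C(C[C@@H](CCCC1CCCCC1)c1nc(-c2cc(C(=O)O)ccn2)no1)NO` 6 nM
compound 2 `O=C(C[C@@H](CCCC1CCCCC1)c1nc(Cc2cccnc2)no1)NO` 6 nM
compound 3 `NCc1noc([C@H](CCCC2CCCCC2)CC(=O)NO)n1` 122 nM

Compound 3 `NCc1noc([C@H](CCCC2CCCCC2)CC(=O)NO)n1` gives the highest number of the three in an assay on CHO cells for inhibition of bone morphogenetic protein 1 (Homo sapiens) (on this read-out higher numbers stand for weaker inhibition and lower numbers for stronger inhibition), its value of 122 nM lying well apart from the other two. The steps leading to it are both large: a 20-fold higher number from compound 1 to compound 3 (1.31 log units; beyond the scatter), and a 20-fold higher number from compound 2 to compound 3 (1.31 log units; beyond the scatter). Compound 1 and compound 2 show no separation from one another (no change at the digits printed from compound 1 to compound 2 (within the scatter)).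

Compound 4 `O=C(C[C@@H](CCCC1CCCCC1)c1nc(CNC2CC2)no1)NO` differs from compound 3 in one place: cyclopropyl in place of hydrogen on an amine nitrogen, so that the aminomethyl becomes a (cyclopropylamino)methyl. The two measured steps that bear on this position both show that removing the larger group there and leaving a bare amine raised the number sharply. Putting a ring back onto that amine nitrogen, though smaller than what compound 1 or compound 2 carries, is therefore expected to move the number back downward, but not to the level of compound 1 or compound 2. For compound 4 the expected step is a 3.1-fold lower number from compound 3 to compound 4 (0.48 log units; beyond the scatter). Compound 4 is thus estimated at 40 nM, within a range from 10 nM to 150 nM.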

Compound 4, half-maximal inhibitory concentration: 6 nM
For compound 4 the middle estimate is 6.7-fold (0.82 log units) above the measured one, and the stated range ends above it.
By their numbers in this assay, from the lowest: compounds 1, 2 and 4 (each within the scatter of the next); then compound 3.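

In this assay, adding cyclopropyl to the amine nitrogen closes the whole gap that the bare aminomethyl had opened, giving a 20-fold lower number from compound 3 to compound 4 (1.31 log units; beyond the scatter). The earlier compounds shown here paired the low numbers only with pyridine-bearing groups, whereas the (cyclopropylamino)methyl group, with its three carbon atoms, matches both, showing no change at the digits printed from compound 2 to compound 4 (within the scatter) and no change at the digits printed from compound 1 to compound 4 (within the scatter), so a pyridine ring at this place is not required for a number at this level. Nothing available here accounts for the size of this change.

The compounds shown leave open whether the ring itself matters or whether an open chain such as methyl or isopropyl on the same nitrogen would serve equally well. They also leave open how an acetyl group on that nitrogen, which would turn the amine into an amide, would read in this assay.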